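Benzyl ring variation in the arylthio dihydropyrimidine series

This account rests on a few compounds, and the source may have more. Where it says the series, first, only, none or still open, it means among the compounds named here.

Compound 3 `CC1=C(C(=O)Nc2ccc(Br)cc2)C(c2ccc(Cl)cc2Cl)N=C(SCc2cccc(Cl)c2)N1` is the lowest of the three compounds measured in a functional assay on the whole organism (artery, strain albino) with Rattus norvegicus as the target, with a stated time of 300 min, at a dose of 10 mg/kg by the oral route (on this read-out lower numbers stand for less inhibition and higher numbers for more inhibition at the one dose given (going by the name of the read-out)), giving 18.5%. Its nearest neighbour is compound 2 `CC1=C(C(=O)Nc2ccc(Br)cc2)C(c2ccc(Cl)cc2Cl)N=C(SCc2ccccc2Cl)N1`, which in this assay gives 36.4%; furthest away is compound 1 `CC1=C(C(=O)Nc2ccc(F)cc2)C(c2ccc([N+](=O)[O-])cc2)N=C(SCc2ccccc2)N1`, which in this assay gives 38.5%. Both gaps lie beyond the scatter.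

Compound 4 `CC1=C(C(=O)Nc2ccc(Br)cc2)C(c2ccc(Cl)cc2Cl)N=C(SCc2ccc(F)cc2)N1` is not yet measured. It differs from compound 3 only at the benzyl ring: 4-fluorophenyl in place of 3-chlorophenyl on a saturated chain carbon bound to a sulfur.

Among the measured compounds shown here, one measured step bears on this change, as it alters the same ring on the saturated chain carbon bound to a sulfur: a number 17.9 percentage points lower from compound 2 to compound 3 (beyond the scatter). That step shows that a change of substituent on this ring can shift the read-out by a modest amount beyond the scatter. Compound 1, with an unsubstituted benzyl ring, sits close to compound 2, so no single direction is set by the three values. Nothing measured tells how a 4-fluorophenyl group behaves here, so the expected step for compound 4 is placed between the two chlorophenyl cases, with a wide range.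

Compound 4 is therefore estimated at 29% in this assay, between 12% and 46%. This corresponds to an expected step of a number 10.5 percentage points higher from compound 3 to compound 4 (beyond the scatter).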

Compound 4, a percentage reported as inhibition, in the whole organism at one dose (the size of the read-out at that dose, not a potency): 38.5%
For compound 4 the middle estimate is 9.5 percentage points below the measured one, within the range that was stated.
By their numbers in this assay, from the lowest: compound 3; then compounds 2, 1 and 4 (each within the scatter of the next).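

In this assay, the low reading at this position now looks tied to the 3-chlorophenyl group rather than to halogen-bearing benzyl rings in general, with a number 20 percentage points higher from compound 3 to compound 4 (beyond the scatter). The two groups compared here, 2-chlorophenyl and 4-fluorophenyl, are not separated on the saturated chain carbon bound to a sulfur, with a number 2.1 percentage points higher from compound 2 to compound 4 (within the scatter); among the three compounds that differ only at this ring, compound 3 is therefore the one that stands apart, while compound 2 and compound 4 form a level group. No measurement available here gives a reason for this difference.

The change from 3-chlorophenyl to 4-fluorophenyl alters the halogen and its ring numbering together, so these compounds cannot tell which of the two goes with the higher reading; 3-fluorophenyl and 4-chlorophenyl groups would pull these apart on the same core. Also open, going by these compounds, is whether anything other than a halogen on this ring, such as a methoxy group or an amine, keeps the reading at the level of compound 2 and compound 4.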